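Compound 2 to compound 3: bromo in place of chloro

A few compounds are considered here, and "the series" means these few. Any claim that something is new, unique, unknown or untested is made for them only; others in the source may bear on it.

In a toxicity assay on Vero cells (Chlorocebus sabaeus) for inhibition, read by MTT assay, with a stated time of 48 h (on this read-out lower numbers stand for stronger inhibition and higher numbers for weaker inhibition), compound 1 (`COc1ccc(/C=C2\N=C3C=CC=CN3C2=O)cc1`) gives 1500 nM while compound 2 (`O=C1/C(=C/c2ccc(Cl)cc2)N=C2C=CC=CN12`) gives 200 nM and holds the lower of the two numbers. Compound 3 (`O=C1/C(=C/c2ccc(Br)cc2)N=C2C=CC=CN12`) differs from compound 2 by one change (bromo in place of chloro on an aromatic carbon) with bromo in place of chloro on an aromatic carbon. Among the compounds with values here, the only measured step is a 7.5-fold lower number from compound 1 to compound 2 (0.88 log units; beyond the scatter) for chloro in place of methoxy, a modest step that involves a different exchange and offers limited guidance here. Within the data shown here, no step between two halogens has been measured. No step beyond the scatter is therefore expected in this assay and no direction is favoured. The estimate means no change at the digits printed from compound 2 to compound 3 (within the scatter) as the expected step. Compound 3 is expected at 200 nM with an estimated range from 80 nM to 500 nM in this read-out.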

Compound 3, half-maximal inhibitory concentration: 200 nM
For compound 3 middle estimate and measured number coincide at the digits printed; measured number inside the range.
By their numbers in this assay, from the lowest: compounds 2 and 3 (each within the scatter of the next); then compound 1.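

In this assay bromo and chloro are interchangeable on this aromatic carbon, with no change at the digits printed from compound 2 to compound 3 (within the scatter) for the exchange. Bromo in place of methoxy gives a 7.5-fold lower number from compound 1 to compound 3 (0.88 log units; beyond the scatter) as its step, so the gap from the methoxy compound is not particular to chloro but holds for both halogens shown. No measurement at hand bears on the reason for either step.

On these data alone, whether the same gap holds for fluoro stays open. So does the outcome with an amine or a carboxylic acid on this aromatic carbon.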